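This account rests on a few compounds, and the source may have more. Where it says the series, first, only, none or still open, it means among the compounds named here.

In a functional assay on T-24 cells (Homo sapiens) for cytotoxicity, read by colorimetric assay and MTT assay (a higher number here means a weaker inhibitor, a lower number a stronger inhibitor), compound 1 `CCOC(=O)Cn1c(=O)c(-c2ccc(OC)cc2)cc2c(OC)cc(OC)cc21` gives 10000 nM. Compound 2 `CCN(CC)C(=O)Cn1c(=O)c(-c2ccc(OC)cc2)cc2c(OC)cc(OC)cc21` gives 10000 nM, which places compound 2 level with compound 1. For the measured compounds named here, putting diethylamino in place of ethoxy on a carbonyl carbon produced no change at the digits printed from compound 1 to compound 2 (within the scatter), and this is the only measured step available as a guide.

Compound 3 `COc1ccc(-c2cc3c(OC)cc(OC)cc3n(CC#N)c2=O)cc1` has not yet been measured. It keeps the shared core but carries cyano in place of diethylcarbamoyl on a saturated chain carbon bound to an aromatic nitrogen. This change removes the carbonyl itself, so the measured step, which only altered what sits on that carbonyl, is a limited guide. With no measured step beyond the scatter, none is expected in this assay here either. The expected step is no change at the digits printed from compound 2 to compound 3 (within the scatter). Compound 3 is estimated at 10000 nM, within an expected range of 4000 nM to 20000 nM.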

Compound 3, half-maximal inhibitory concentration: 10000 nM
Compound 3: the middle estimate sits on the measured number at the digits printed; the range from low to high includes it.
By their numbers in this assay, from the lowest: compounds 1, 2 and 3 (each within the scatter of the next).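

In this assay, the earlier step altered only what sits on the carbonyl, whereas this change removes the carbonyl itself: cyano in place of diethylcarbamoyl on a saturated chain carbon bound to an aromatic nitrogen gives no change at the digits printed from compound 2 to compound 3 (within the scatter) and cyano in place of ethoxycarbonyl gives no change at the digits printed from compound 1 to compound 3 (within the scatter) as well. Across these three compounds, then, the read-out stays the same whether this carbon bears ethoxycarbonyl, diethylcarbamoyl or cyano, even though cyano has 2 heavy atoms and diethylcarbamoyl has 7. No available evidence accounts for this flat result.

From the compounds shown here alone, it remains open whether any group at this position can move the value at all, such as a carboxylic acid, an amine or a longer chain. Going by these compounds, the methoxy groups stay the same across all three compounds, so their part in the result also remains open.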